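Triazole-linked coumarin isatins: nitro removal on the shared core

The compounds below may be only part of what the source reports. "The series", "measured", "known", "first", "only" and "open" are said of these compounds alone.

Measured compounds and values in a functional assay on PC-3 cells (Homo sapiens) for inhibition, read by sulforhodamine B assay, with a stated time of 48 h, tested at 50 uM; on this read-out higher numbers stand for more inhibition of growth at the one concentration tested and lower numbers for less inhibition of growth:
- compound 1, `O=C1C(=O)N(CCCCCn2cc(COc3cc(=O)oc4ccccc34)nn2)c2ccccc21`: 9%
- compound 2, `O=C1C(=O)N(CCCCn2cc(COc3cc(=O)oc4ccccc34)nn2)c2ccc([N+](=O)[O-])cc21`: 8%
- compound 3, `O=C1C(=O)N(CCCn2cc(COc3cc(=O)oc4ccccc34)nn2)c2ccc(Cl)cc21`: 18%

All three compounds share the coumarin-triazole-isatin arrangement and differ in the length of the linking chain and in the substituent on the isatin ring. On the numbers shown, compound 2 gives the smallest figure of the three, but the gap to compound 1 and the gap to compound 3 both fall within the usual scatter, so none of the three can be set apart from the others in this assay.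

Compound 4, `O=C1C(=O)N(CCCCn2cc(COc3cc(=O)oc4ccccc34)nn2)c2ccccc21`, is not yet measured. It differs from compound 2 in one place: hydrogen in place of nitro on an aromatic carbon. The chain between the isatin nitrogen and the triazole is the same in both.

For the measured compounds named here, no measured pair isolates this change, so there is nothing in the data that ties the nitro group to a shift in this assay. Compound 1, which also carries hydrogen at that place on a longer chain, sits within the scatter of compound 2. The step from compound 2 to compound 4 is therefore expected to be none beyond the scatter, a number 2 percentage points higher from compound 2 to compound 4 (within the scatter). Compound 4 is estimated at 10%, with a range from 0% to 22%.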

Compound 4, percent growth inhibition at one concentration: 19%
Beside the measured number, compound 4's estimate is 9 percentage points below it; the range from low to high includes it.
By their numbers in this assay, from the lowest: compounds 2, 1, 3 and 4 (each within the scatter of the next, the first and the last beyond it).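

In this assay, for the compounds shown here, a number 11 percentage points higher from compound 2 to compound 4 (beyond the scatter) is the first step that isolates one change, hydrogen in place of nitro on an aromatic carbon, with the chain held the same. It shows that this place is not indifferent to what it carries: among compounds with this chain, the nitro compound gives the lower number, although the step is modest and compound 4 still reaches only 19% at the one concentration tested. Nothing available accounts for the step, so it stands as a measured difference for this one pair.

As far as these compounds go, whether the step is particular to nitro remains open, since a single pair cannot show how an amine, a methoxy group or a fluorine at the same aromatic carbon would read against hydrogen. From the compounds shown here alone, it is also open whether hydrogen in place of nitro gives a step of similar size on a shorter chain or on a longer one, so the result should be kept to this chain and this position for now.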